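Allyl to 3-methylbenzyl: a step expected within scatter

This account rests on a few compounds, and the source may have more. Where it says the series, first, only, none or still open, it means among the compounds named here.

compound 1, `COc1ccc([C@@H]2CC(=O)c3c(O)cc(OCc4cn(Cc5ccccc5C(F)(F)F)nn4)cc3O2)cc1O`: 12500 nM
compound 2, `C=CCn1cc(COc2cc(O)c3c(c2)O[C@H](c2ccc(OC)c(O)c2)CC3=O)nn1`: 13800 nM

Among the compounds with values here, in a functional assay on RAW264.7 cells (Mus musculus) for inhibition, read by Griess assay, with stated times of 2 h and 24 h (on this read-out lower numbers stand for stronger inhibition and higher numbers for weaker inhibition), compound 2 gives 13800 nM, the upper of the two numbers so far, with compound 1 nearest at 12500 nM; the step of a 1.1-fold higher number from compound 1 to compound 2 (0.04 log units; within the scatter) separates them, so the two compounds cannot be told apart on this read-out. Compound 3, `COc1ccc([C@@H]2CC(=O)c3c(O)cc(OCc4cn(Cc5cccc(C)c5)nn4)cc3O2)cc1O`, has not been measured. It differs from compound 2 by 3-methylphenyl in place of vinyl on a saturated chain carbon bound to an aromatic nitrogen. Within the data shown here, the one measured step that bears on this change is the one from compound 1 to compound 2, where an aromatic group on that same chain carbon was exchanged for vinyl and the number moved by a 1.1-fold higher number from compound 1 to compound 2 (0.04 log units; within the scatter). Compound 3 reverses that kind of exchange, putting an aromatic group back in place of vinyl, with a different substituent on the ring. On that basis the step of a 1.1-fold lower number from compound 2 to compound 3 (0.04 log units; within the scatter) is expected to stay within the scatter, in no clear direction. Compound 3 is therefore estimated at 12500 nM in this assay, with a range from 7000 nM to 23000 nM.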

Compound 3, half-maximal inhibitory concentration: 17400 nM
Compound 3: the middle estimate sits 1.4-fold (0.14 log units) below what was measured; measured number inside the range.
By their numbers in this assay, from the lowest: compounds 1, 2 and 3 (each within the scatter of the next).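

In this assay a third group on the saturated chain carbon bound to an aromatic nitrogen again leaves the read-out within the scatter. Putting 3-methylphenyl in place of vinyl gives a 1.3-fold higher number from compound 2 to compound 3 (0.10 log units; within the scatter) and putting it in place of 2-(trifluoromethyl)phenyl gives a 1.4-fold higher number from compound 1 to compound 3 (0.14 log units; within the scatter) on the same read-out. Within the data shown here, the earlier pair had set only one aromatic group against vinyl, whereas compound 3 adds a second aromatic group with a different substituent, and this assay separates none of the three groups, so across compound 1, compound 2 and compound 3 the change from allyl to a substituted benzyl group has no readable effect.

All three groups shown at this position are built of carbon apart from the fluorines of the trifluoromethyl group, so it remains open whether an amine, a carboxylic acid or a hydroxyl group on the same chain carbon would also stay within the scatter, and whether a longer chain would. No measurement at hand gives any account of why these three groups read alike.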